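Chain extension on the core: propyl after ethyl

A few compounds are considered here, and "the series" means these few. Any claim that something is new, unique, unknown or untested is made for them only; others in the source may bear on it.

Compound 2 `CCCN(CC1CCOC1)C(=O)c1cc(CC)c2oc(NCc3cccc(Cl)c3)nc2c1` differs from compound 1 `CCCN(CC1CCOC1)C(=O)c1cc(C)c2oc(NCc3cccc(Cl)c3)nc2c1` only in the alkyl group on the core, ethyl in place of methyl. In an assay on isolated protein for inhibition of thyroid hormone receptor beta (Homo sapiens), read by fluorescence, with a stated time of 30 min (on this read-out lower numbers stand for stronger inhibition and higher numbers for weaker inhibition), compound 1 gives 35 nM and compound 2 gives 104 nM. The step is a 3.0-fold higher number from compound 1 to compound 2 (0.47 log units; beyond the scatter), a weakening. Within the data shown here, of the two numbers measured so far, compound 2 therefore holds the higher one, and its nearest neighbour in this assay is compound 1.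

Compound 3 `CCCc1cc(C(=O)N(CCC)CC2CCOC2)cc2nc(NCc3cccc(Cl)c3)oc12` takes the same chain one carbon further: methyl in place of hydrogen on a saturated chain carbon, two bonds along the chain from an aromatic carbon. Among the measured compounds shown here, the only measured step that bears on this change is a 3.0-fold higher number from compound 1 to compound 2 (0.47 log units; beyond the scatter), which ran in the weakening direction beyond the scatter. Extending ethyl to propyl is a smaller relative change than methyl to ethyl, so a step of similar direction but no larger size is expected here, and one within the scatter cannot be excluded. The expected step is a 1.9-fold higher number from compound 2 to compound 3 (0.28 log units; within the scatter). For compound 3 the estimate in this assay is 200 nM, with a range from 80 nM to 500 nM.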

Compound 3, half-maximal inhibitory concentration: 957 nM
Compound 3: the middle estimate sits 4.8-fold (0.68 log units) below what was measured; measured number above the stated range.
By their numbers in this assay, from the lowest: compound 1; then compound 2; then compound 3.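

At this position the weakening in this assay does not level off as the chain grows: going from ethyl to propyl gives a 9.2-fold higher number from compound 2 to compound 3 (0.96 log units; beyond the scatter) and is no smaller than the earlier 3.0-fold higher number from compound 1 to compound 2 (0.47 log units; beyond the scatter) for methyl to ethyl. Across the whole series, propyl in place of methyl gives a 27-fold higher number from compound 1 to compound 3 (1.44 log units; beyond the scatter) and makes compound 3 the weakest of the three, so the number rises with each added carbon, and none of the three compounds goes against that order. No measurement available here explains why the propyl chain costs so much.

Still open, from the compounds shown here alone, is how a butyl chain, a branched isopropyl group, a cyclopropyl ring or a methoxy group would read at this place on the shared core, and whether plain hydrogen there would give a lower number than compound 1 does. Also open, going by these compounds, is whether the same rise from methyl to propyl would hold with another amide group or with a different group in place of the chlorobenzyl amine, since all three compounds carry the same two groups.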